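This account rests on a few compounds, and the source may have more. Where it says the series, first, only, none or still open, it means among the compounds named here.

Working notes on the series. The core of compound 1 `O=C(O)c1cc(-n2ccnn2)ccc1O` anchors the set. In a functional assay on the whole organism for inhibition, with Rattus norvegicus as the target, read by paw edema (on this read-out lower numbers stand for an effect already at smaller amounts and higher numbers for an effect only at larger amounts of compound), compound 1 gives 150 mg/kg. Compound 3 `CC(=O)Oc1ccc(-n2cccc2)cc1C(=O)O` gives 42 mg/kg. Compound 2 `O=C(O)c1ccc(-c2ncco2)cc1O` reaches only a limit of the assay, > 250 mg/kg. Of the two numbers, compound 1 stands highest, with compound 3 a step beyond the scatter below it. The further value, that of compound 2, is a limit (the limit of > 250 mg/kg in this assay, at which 1 of the 3 values shown sits). Compound 4 `O=C(O)c1cc(-c2cncs2)ccc1O` is not yet measured; it differs from compound 1 by 1,3-thiazol-5-yl in place of 1H-1,2,3-triazol-1-yl on an aromatic carbon. Going by the values given here, no measured pair isolates this change, since compound 2 and compound 3 differ from compound 1 in more than one place. The step from compound 1 to compound 4 in this assay is expected to stay within the scatter, no change at the digits printed from compound 1 to compound 4 (within the scatter). For compound 4 the expected value is 150 mg/kg, in a range from 60 mg/kg to 300 mg/kg.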

Compound 4, dose for half-maximal effect: > 200 mg/kg
Compound 4 ended at the assay's limit; the forecaster's own chance of this, stated with the estimate: 30%; at least 1.3-fold (0.12 log units) between middle value and limit.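

In this assay, going by these compounds alone, the change to 1,3-thiazol-5-yl in place of 1H-1,2,3-triazol-1-yl, on the aromatic carbon meta to the carboxy group and para to the hydroxy group, gives an at least 1.3-fold higher number from compound 1 to compound 4 (0.12 log units; that floor lies within the scatter) and forms the first pair that isolates one change at this place. This pair therefore yields only a floor, and that floor does not separate the two groups. Compound 4 stands at a limit of the assay and not at a number: the limit of > 200 mg/kg in this assay, at which 1 of the 4 values shown sits.

From the compounds shown here alone, how far compound 4 lies past its limit stays open. Also open, going by these compounds, is how an amine or a carboxylic acid at this place would read out in this assay.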